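From isopropyl to cyclopropyl on the shared core

A few compounds are considered here, and "the series" means these few. Any claim that something is new, unique, unknown or untested is made for them only; others in the source may bear on it.

Measured in a physicochemical assay for solubility, in phosphate buffer, with a stated time of 18 h (on this read-out higher numbers stand for higher solubility and lower numbers for lower solubility), so far
- compound 1 `CC(C)(C)c1nc(-c2ccc[nH]2)c2cc(C(N)=O)c(N)nc2n1` gives 130000 nM
- compound 2 `Cc1ncc2c(N)c(C#N)c(N)nc2n1` gives 783000 nM
- compound 3 `CC(C)c1ncc2c(N)c(C#N)c(N)nc2n1` gives > 1000000 nM

Compound 3 gives > 1000000 nM as a limit and not a number, and it stands at the limit of > 1000000 nM in this assay, at which 1 of the 3 values shown sits, on this scale. Compound 4 `N#Cc1c(N)nc2nc(C3CC3)ncc2c1N` differs from it as follows: cyclopropyl in place of isopropyl on an aromatic carbon with cyclopropyl in place of isopropyl on an aromatic carbon. Among the measured compounds shown here, one measured step bears on this change: an at least 1.2-fold higher number from compound 2 to compound 3 (0.10 log units; that floor lies within the scatter) on an aromatic carbon. With that single step as the guide, no step beyond the scatter is expected in this assay for compound 4. The expected step is an at least 1.1-fold lower number from compound 3 to compound 4 (0.07 log units; that floor lies within the scatter) in this estimate. Compound 4 is estimated at 850000 nM with a range from 400000 nM to 1600000 nM in this read-out.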

Compound 4, solubility: 23000 nM
Beside the measured number, compound 4's estimate is 37-fold (1.57 log units) above it, outside the stated range (below it).
By their numbers in this assay, from the lowest: compound 4; then compound 1; then compound 2. At a limit, above all of these: compound 3.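

In this assay, this position turns out to be sensitive to the group it carries: isopropyl and cyclopropyl have the same count of heavy atoms, yet the exchange gives an at least 43-fold lower number from compound 3 to compound 4 (1.63 log units; beyond the scatter). Cyclopropyl in place of methyl likewise gives a 34-fold lower number from compound 2 to compound 4 (1.53 log units; beyond the scatter). Compound 3 stands at a limit and not a number: the limit of > 1000000 nM in this assay, at which 1 of the 4 values shown sits.

From the compounds shown here alone, the full size of the first step therefore stays open. Going by these compounds, it also remains unknown how a cyclobutyl ring, a longer chain or an amine on this aromatic carbon would read, and so whether the fall belongs to the three-membered ring alone.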